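The compounds below may be only part of what the source reports. "The series", "measured", "known", "first", "only" and "open" are said of these compounds alone.

Compound 1, `CCCS(=O)(=O)Nc1ccc(F)c(C(=O)c2n[nH]c3ncc(-c4cccc(OC)c4)cc23)c1F`, gives 6.3% in an assay for binding affinity to dual specificity mitogen-activated protein kinase kinase 4 (Homo sapiens), read by KINOMEscan, tested at 100 nM; on this read-out higher numbers stand for a weaker effect at the one concentration tested and lower numbers for a stronger effect.
Compound 2, `CCCS(=O)(=O)Nc1ccc(F)c(C(=O)c2n[nH]c3ncc(-c4ccc(Cl)c(C(F)(F)F)c4)cc23)c1F`, gives 15% in this assay.

Among the measured compounds shown here, compound 2 stands highest of the two numbers, with compound 1 nearest, and the one measured step, a number 8.7 percentage points higher from compound 1 to compound 2 (within the scatter), lies within the scatter. Compound 3, `CCCS(=O)(=O)Nc1ccc(F)c(C(=O)c2n[nH]c3ncc(-c4ccc(C(=O)O)cc4)cc23)c1F`, differs from compound 2 in one place: 4-carboxyphenyl in place of 4-chloro-3-(trifluoromethyl)phenyl on an aromatic carbon. For the measured compounds named here, no measured step involves a carboxyphenyl group. Going by the values given here, the step of a number 8.7 percentage points higher from compound 1 to compound 2 (within the scatter) shows only that one exchange of this aryl group stayed within the scatter. The step of a number 7 percentage points higher from compound 2 to compound 3 (within the scatter) is therefore expected to be small. Compound 3 is estimated at 22% in this assay, from 4% to 65%.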

Compound 3, a percentage reported as activity, at one concentration (the size of the read-out at that concentration, not a potency): 0.1%
For compound 3 the middle estimate is 21.9 percentage points above the measured one, and the stated range ends above it.
By their numbers in this assay, from the lowest: compounds 3, 1 and 2 (each within the scatter of the next, the first and the last beyond it).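

Within this assay, this aromatic carbon now shows its first exchange beyond the scatter (a number 14.9 percentage points lower from compound 2 to compound 3 (beyond the scatter)), with 4-carboxyphenyl replacing 4-chloro-3-(trifluoromethyl)phenyl. Against 3-methoxyphenyl, the same group stays within the scatter (a number 6.2 percentage points lower from compound 1 to compound 3 (within the scatter)), so the change registers against only one of the two earlier aryl groups. Nothing available here explains that difference.
The compounds shown leave open whether an amine in place of the carboxylic acid, or a longer chain carrying that acid, would keep the number of compound 3 (0.1%) in this assay.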